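The source may report more compounds than this note shows. Statements on the series, on what has been measured and on what is new or still open speak of the compounds shown alone.

Measured compounds in the series so far:

Compound 1 `CN(C)CCCn1cnnc1-c1cc(Oc2ccc(NC(=O)Nc3ccccc3C(F)(F)F)cc2F)ccn1`: 40500 nM
Compound 2 `CN(C)CCCn1cnnc1-c1cc(Oc2ccc(NC(=O)Nc3ccc(F)c(F)c3)cc2F)ccn1`: 25300 nM

Both numbers come from a functional assay on MDA-MB-231 cells (Homo sapiens) for antiproliferative activity, read by MTT assay, with a stated time of 72 h; on this read-out lower numbers stand for stronger inhibition and higher numbers for weaker inhibition. In this assay compound 1 gives 40500 nM and compound 2 gives 25300 nM. Going by the values given here, the one measured step, a 1.6-fold lower number from compound 1 to compound 2 (0.20 log units; within the scatter), replaces the whole aryl group on the urea nitrogen and does not move the number beyond the scatter. Compound 2 therefore stands at the lower of the two numbers, but it is not separated from compound 1 in any meaningful way.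

Compound 3 `CN(C)CCCn1cnnc1-c1cc(Oc2ccc(NC(=O)Nc3ccc(F)c(Cl)c3)cc2F)ccn1` is the next member. It differs from compound 2 by chloro in place of fluoro on an aromatic carbon. Among the compounds with values here, no measured step exchanges a single halogen for another; the only step available, a 1.6-fold lower number from compound 1 to compound 2 (0.20 log units; within the scatter), is a larger change and still stays within the scatter. Nothing in the data therefore supports expecting a step beyond the scatter for compound 3, and the expected step is a 1.3-fold lower number from compound 2 to compound 3 (0.10 log units; within the scatter). On that basis compound 3 is estimated at 20000 nM in this assay, with a range from 8000 nM to 50000 nM.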

Compound 3, half-maximal inhibitory concentration: 14200 nM
Beside the measured number, compound 3's estimate is 1.4-fold (0.15 log units) above it; the measured number falls inside the stated range.
By their numbers in this assay, from the lowest: compounds 3, 2 and 1 (each within the scatter of the next, the first and the last beyond it).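

In this assay, the series now holds a single-halogen exchange: chloro in place of fluoro on an aromatic carbon, ortho to a fluoro group, gives a 1.8-fold lower number from compound 2 to compound 3 (0.25 log units; within the scatter) and so leaves compound 2 and compound 3 unseparated at this position. Going by these compounds alone, the change of the whole aryl group on the amide-type nitrogen to 3-chloro-4-fluorophenyl gives the first step beyond the scatter, a 2.9-fold lower number from compound 1 to compound 3 (0.46 log units; beyond the scatter), though it is modest, whereas the 3,4-difluorophenyl group of compound 2 is not separated from the 2-(trifluoromethyl)phenyl group of compound 1. No measurement at hand accounts for the size of either step.

Still open, as far as these compounds go, is whether bromo, methyl or methoxy on this same aromatic carbon would stay within the scatter of chloro, or whether the step beyond the scatter would grow with any of them. Also open, from the compounds shown here alone, is how the numbers would respond if the dimethylamine at the end of the chain on the shared core gave way to a morpholine, a carboxylic acid or a longer chain.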